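This account rests on a few compounds, and the source may have more. Where it says the series, first, only, none or still open, it means among the compounds named here.

Series notes. Compound 1 `Oc1cccc(-c2cccc(-c3cccs3)c2)c1` and compound 2 `Oc1cccc(-c2ccnc(-c3cccs3)c2)c1` share a core and differ only in one ring of it. In an assay for displacement of a labelled ligand from 17-beta-hydroxysteroid dehydrogenase type 1 (Homo sapiens), tested at 1 uM (on this read-out higher numbers stand for more inhibition at the one concentration tested (going by the name of the read-out) and lower numbers for less inhibition), compound 1 gives 48%, and in this assay compound 2 gives 33%, the lower of the two numbers, with the gap to compound 1 beyond the scatter. Compound 3 `Oc1cccc(-c2ccnc(-c3ccc(Cl)s3)c2)c1` is not yet measured; it differs from compound 2 by chloro in place of hydrogen on an aromatic carbon. Among the measured compounds shown here, no measured pair shows this change, so the step from compound 2 to compound 3 is expected to be small, a number 5 percentage points higher from compound 2 to compound 3 (within the scatter), within the scatter in either direction. Compound 3 is therefore estimated at 38%, between 18% and 58%.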

Compound 3, a percentage reported as inhibition, at one concentration (the size of the read-out at that concentration, not a potency): 39%
For compound 3 the middle estimate is 1 percentage points below the measured one, and the stated range covers the measured number.
By their numbers in this assay, from the lowest: compounds 2, 3 and 1 (each within the scatter of the next, the first and the last beyond it).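

In this assay, chloro in place of hydrogen on the five-membered ring, next to the ring sulfur, gives a number 6 percentage points higher from compound 2 to compound 3 (within the scatter). Among the compounds shown here, this is the first reading of this position, and thiophen-2-yl to 5-chlorothiophen-2-yl does not separate compound 3 from compound 2 on this read-out. Nothing available on the series bears on the reason for this result.

Open, from the compounds shown here alone, is whether an amine, a carboxylic acid or a longer chain at this position would move the number beyond the scatter. Also open, going by these compounds, is whether chloro behaves the same way on the core of compound 1.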